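The source may report more compounds than this note shows. Statements on the series, on what has been measured and on what is new or still open speak of the compounds shown alone.

Compound 2 `COc1cc(-c2nnc(SCC(=O)c3ccc(C)cc3)n2N2C(=O)c3ccccc3C2=O)cc(OC)c1OC` in a functional assay on PC-3M cells (Homo sapiens) for cytotoxicity, read by MTT assay, with a stated time of 48 h (on this read-out higher numbers stand for weaker inhibition and lower numbers for stronger inhibition), gives 11700 nM. Compound 1 `COc1cc(-c2nnc(SCc3ccccc3Cl)n2N2C(=O)c3ccccc3C2=O)cc(OC)c1OC` in this assay gives only a limit, > 200000 nM. Going by the values given here, the single measured step, an at least 17-fold lower number from compound 1 to compound 2 (1.23 log units; beyond the scatter), rests on (the limit of > 200000 nM in this assay, at which 1 of the 2 values shown sits); its true size is therefore known only as a minimum. Compound 2 thus carries the only number shown, the other value being a limit. Compound 3 `COc1cc(-c2nnc(SC)n2N2C(=O)c3ccccc3C2=O)cc(OC)c1OC` is not yet measured; its change from compound 2 is hydrogen in place of (4-methylphenyl)carbonyl on a saturated chain carbon bound to a sulfur. Among the compounds with values here, the one measured step sits at the same saturated chain carbon bound to a sulfur and shows that exchanging the group there moved the number by a large amount. Taking the (4-methylphenyl)carbonyl away altogether is expected to move the number back up, a step of a 6.8-fold higher number from compound 2 to compound 3 (0.83 log units; beyond the scatter), with a fair chance that only a limit is returned. Compound 3 is therefore expected to give 80000 nM, in the range 20000 nM to 300000 nM.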

Compound 3, half-maximal inhibitory concentration: > 200000 nM
Compound 3 gave a limit, no number; the forecaster's own chance of this, stated with the estimate: 40%; middle value at least 2.5-fold (0.39 log units) from the limit.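

Taking the (4-methylphenyl)carbonyl away from the saturated chain carbon bound to a sulfur gives an at least 17-fold higher number from compound 2 to compound 3 (1.23 log units; beyond the scatter) in this assay, so hydrogen at this place, like 2-chlorophenyl, returns no number. Of the three groups shown there, only (4-methylphenyl)carbonyl gives a number, and the true size of this step is known only as a minimum. The step from compound 1 to compound 3 cannot be read, as both compounds give only a limit: the limit of > 200000 nM in this assay, at which 2 of the 3 values shown sit.

The compounds shown leave open which part of the (4-methylphenyl)carbonyl goes with the measurable number, the carbonyl, the aromatic ring or the methyl on it. Phenylcarbonyl, which lacks that methyl, and methylcarbonyl, which lacks the ring, would separate these parts.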